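Benzofuran in place of thiophene on a nucleoside core

The source may report more compounds than this note shows. Statements on the series, on what has been measured and on what is new or still open speak of the compounds shown alone.

Compound 1 `COc1ncnc2c1c(-c1ccsc1)cn2[C@@H]1O[C@H](CO)[C@@H](O)[C@H]1O` is the starting point. In a functional assay on CEM-DNR-bulk cells (Homo sapiens), read by MTT assay, with a stated time of 72 h (a higher number here means a weaker inhibitor, a lower number a stronger inhibitor), compound 1 gives 7640 nM. Of the two numbers shown it has the lowest, and the nearest is compound 2 `Cc1ncnc2c1c(-c1ccsc1)cn2[C@@H]1O[C@H](CO)[C@@H](O)[C@H]1O`, which in this assay gives 8560 nM; the step of a 1.1-fold higher number from compound 1 to compound 2 (0.05 log units; within the scatter) lies within the scatter. Compound 3 `CSc1ncnc2c1c(-c1ccsc1)cn2[C@@H]1O[C@H](CO)[C@@H](O)[C@H]1O` reaches only a limit of this assay: compound 3 gives > 20000 nM, which is a limit and not a number (the limit of > 20000 nM in this assay, at which 1 of the 3 values shown sits). The steps of an at least 2.6-fold higher number from compound 1 to compound 3 (0.41 log units; beyond the scatter) and an at least 2.3-fold higher number from compound 2 to compound 3 (0.36 log units; beyond the scatter) are beyond the scatter.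

Compound 4 `COc1ncnc2c1c(-c1cc3ccccc3o1)cn2[C@@H]1O[C@H](CO)[C@@H](O)[C@H]1O` has not been measured in this assay. It differs from compound 1 in one place: 1-benzofuran-2-yl in place of thiophen-3-yl on an aromatic carbon. All three measured steps change the group on the six-membered ring of the core, not the five-membered aromatic ring that carries the thiophen-3-yl group, so none of them bears on this change. The account therefore rests on compound 1 alone, and the expected size of the step is uncertain in both directions. The estimated step is a 2.2-fold lower number from compound 1 to compound 4 (0.34 log units; beyond the scatter). Compound 4 is expected to give about 3500 nM in this assay, within a range from 500 nM to 20000 nM.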

Compound 4, half-maximal inhibitory concentration: 10800 nM
Compound 4: the middle estimate sits 3.1-fold (0.49 log units) below what was measured, within the range that was stated.
By their numbers in this assay, from the lowest: compounds 1, 2 and 4 (each within the scatter of the next). At a limit, above all of these: compound 3.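

In this assay the change reads as a 1.4-fold higher number from compound 1 to compound 4 (0.15 log units; within the scatter), so 1-benzofuran-2-yl, with its added six-membered aromatic ring of carbon only and its oxygen in place of sulfur, stands at this place on the five-membered aromatic ring without a difference from thiophen-3-yl that can be told from the scatter. Among the compounds shown here, this is the first measured step at this place, as the earlier steps all changed the group on the six-membered ring of the core, and it shows that this position accepts a group of 9 heavy atoms as well as one of 5 while the methoxy group stays the same. No information given here explains why the two groups read alike.

The compounds shown leave open whether a saturated group at this place, such as a cyclohexyl ring or a longer alkyl chain, or an amine or a carboxylic acid carried on the aromatic group, would move the number beyond the scatter. They also leave open whether 1-benzofuran-2-yl reads the same way when methyl or methylsulfanyl takes the place of methoxy on the core.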